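From 1-(trifluoromethyl)ethyl to isopropyl on compound 1

The source may hold more compounds than are shown below. What is called first, only, known or untested is meant among the compounds shown, and "the series" means these compounds.

Within the data shown here, in a physicochemical assay for solubility (on this read-out higher numbers stand for higher solubility and lower numbers for lower solubility), compound 1 (`C[C@H](Oc1ccc(S(C)(=O)=O)cc1C(=O)N1Cc2cc(C(F)(F)F)cnc2C1)C(F)(F)F`) gives 280 ug/mL and stands highest of the numbers so far. Compound 3 (`C[C@H](Oc1ccc(S(C)(=O)=O)cc1C(=O)N1Cc2ccc(C3CCOCC3)cc2C1)C(F)(F)F`) sits lower at 76 ug/mL on that scale. Compound 2 (`C[C@H](Oc1ccc(S(C)(=O)=O)cc1C(=O)N1Cc2ccc(C3CCCCO3)cc2C1)C(F)(F)F`) returns only a limit (< 1 ug/mL). Compound 4 (`CC(C)Oc1ccc(S(C)(=O)=O)cc1C(=O)N1Cc2cc(C(F)(F)F)cnc2C1`) carries isopropyl in place of 1-(trifluoromethyl)ethyl on an oxygen on an aromatic ring. Among the measured compounds shown here, no measured step makes this change. For the measured compounds named here, the one step available (an at least 76-fold higher number from compound 2 to compound 3 (1.88 log units; beyond the scatter)) was large but swaps oxan-2-yl for oxan-4-yl on an aromatic carbon, so it shows only that a single change can move this assay strongly. Going by these compounds, no step beyond the scatter is therefore expected, and the direction stays open. The estimated change is a 1.1-fold higher number from compound 1 to compound 4 (0.03 log units; within the scatter) with wide uncertainty. For compound 4 the expected value is 300 ug/mL within a range from 90 ug/mL to 900 ug/mL as an estimate.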

Compound 4, solubility: 114 ug/mL
Compound 4: the middle estimate sits 2.6-fold (0.42 log units) above what was measured; the range from low to high includes it.
By their numbers in this assay, from the lowest: compounds 3 and 4 (each within the scatter of the next); then compound 1. At a limit, below all of these: compound 2.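

At this oxygen on an aromatic ring, the swap of 1-(trifluoromethyl)ethyl for isopropyl gives a step that can be read: in this assay it is a 2.5-fold lower number from compound 1 to compound 4 (0.39 log units; beyond the scatter). Among these compounds, the earlier steps changed a different part of the molecule, so this is the first sign that this position also matters on this scale, although a single pair sets no pattern. Whether a longer chain or an amine at this oxygen would shift the number stays open, and nothing shown gives a reason for this step.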